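The source may hold more compounds than are shown below. What is called first, only, known or untested is meant among the compounds shown, and "the series" means these compounds.

Measured compounds:
- compound 1, `C=CC[C@@H]1O[C@H](COCc2ccccc2)[C@@H](OCc2ccccc2)[C@H](OCc2ccccc2)[C@H]1O`: 15100 nM
- compound 2, `C=C[C@H]1O[C@H](COCc2ccccc2)[C@@H](OCc2ccccc2)[C@H](OCc2ccccc2)[C@H]1O`: "not active" (no number reported)
- compound 3, `C=CC[C@@H]1O[C@H](COCc2ccccc2)[C@@H](OCc2ccccc2)[C@H](OCc2ccccc2)[C@H]1OC(C)=O`: 26900 nM

The three measured compounds share a core that carries three benzyl ethers and differs only at two positions. In a functional assay on HL-60 cells (Homo sapiens) for antiproliferative activity, read by MTT assay (a lower number here means a stronger inhibitor, a higher number a weaker inhibitor), compound 1 gives 15100 nM, while compound 3 gives 26900 nM. The two differ by acetyl in place of hydrogen on an oxygen on a saturated carbon, and the step of a 1.8-fold higher number from compound 1 to compound 3 (0.25 log units; within the scatter) is small. Compound 2 is reported in this assay only as "not active" (no number reported), so no number can be set against compound 1; how the cores of compound 1 and compound 2 differ is not broken down here.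

Compound 4, `C=C[C@H]1O[C@H](COCc2ccccc2)[C@@H](OCc2ccccc2)[C@H](OCc2ccccc2)[C@H]1OC(C)=O`, stands to compound 2 as compound 3 stands to compound 1: it carries acetyl in place of hydrogen on an oxygen on a saturated carbon. This is the same kind of change, at a place described in the same words, on the core of compound 2 rather than that of compound 1. In this assay compound 4 is therefore expected to behave much as compound 2 does, because the step of a 1.8-fold higher number from compound 1 to compound 3 (0.25 log units; within the scatter) on the related core stayed within the scatter, and compound 2 itself gave no number. Compound 4 is thus estimated to be a weak inhibitor, with an expected value near 60000 nM and a likely range from 20000 nM to 200000 nM, with a substantial chance that only a limit is reported.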

Compound 4, half-maximal inhibitory concentration: "not active" (no number reported)
No number was reported for compound 4; no gap can be computed for the estimate.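

In this assay compound 2 and compound 4 are both reported only as "not active", so no step can be read between them. Nothing shown here offers an explanation for this result. The compounds shown leave open whether acetyl in place of hydrogen alters activity at all on the core of compound 2, and how that core compares in number with the core of compound 1.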